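The compounds below may be only part of what the source reports. "The series", "measured", "known", "first", "only" and "open" are said of these compounds alone.

Measured in a functional assay on SW982 cells (Homo sapiens) for inhibition, read by MTT assay, with a stated time of 72 h; on this read-out lower numbers stand for stronger inhibition and higher numbers for weaker inhibition:
compound 1, `COc1cc(OC)c(OC)cc1/C=C/C(=O)c1ccccc1`, > 150000 nM
compound 2, `COc1cc(OC)c(OC)cc1/C=C/C(=O)c1cccc([N+](=O)[O-])c1`, 101000 nM
compound 3, `COc1cc(OC)c(C2CC(=O)c3cc(O)ccc3O2)cc1OC`, > 150000 nM

The value of compound 1 is a limit of the assay, not a number. The value of compound 3 is likewise a limit. Compound 2 alone gives a number, and it sits close to the limit of > 150000 nM in this assay, at which 2 of the 3 values shown sit.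

Compound 4, `COc1cc(OC)c(OC)cc1/C=C/C(=O)c1ccc(Br)cc1`, differs from compound 1 by bromo in place of hydrogen on an aromatic carbon. Going by the values given here, the only measured step that bears on this change is an at least 1.4-fold lower number from compound 1 to compound 2 (0.17 log units; that floor lies within the scatter), a different substituent entering the same ring of the shared core. That step is small and not resolved from the scatter, so for compound 4 no step beyond the scatter is expected in this assay, with at most a slight lean toward a lower number. Compound 4 is estimated at 120000 nM, within 60000 nM to 250000 nM. The expected step is an at least 1.2-fold lower number from compound 1 to compound 4 (0.09 log units; that floor lies within the scatter), and a limit rather than a number remains a likely outcome.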

Compound 4, half-maximal inhibitory concentration: 38200 nM
The estimate for compound 4 lay 3.1-fold (0.50 log units) above the measured number, and the stated range ends above it.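

In this assay, going by these compounds alone, bromo in place of hydrogen on an aromatic carbon, para to a large group, gives an at least 3.9-fold lower number from compound 1 to compound 4 (0.59 log units; beyond the scatter), the first step that clears the scatter. The earlier nitro change on the same ring did not resolve from the scatter: an at least 1.4-fold lower number from compound 1 to compound 2 (0.17 log units; that floor lies within the scatter). The value of compound 1 is a limit, so the bromo step is only a floor: the limit of > 150000 nM in this assay, at which 2 of the 4 values shown sit.

Open, going by these compounds, is whether an amine or a carboxylic acid in this place would lower the number as bromo does. Also open, on these data alone, is whether bromo elsewhere on this ring would match compound 4.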